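The compounds below may be only part of what the source reports. "The series", "measured", "known", "first", "only" and "open" are said of these compounds alone.

Working notes on the series. In a functional assay on the whole organism for inhibition, with Rattus norvegicus as the target, with a stated time of 2 h, at a dose of 100 mg/kg by the oral route (on this read-out higher numbers stand for more inhibition at the one dose given (going by the name of the read-out) and lower numbers for less inhibition), compound 1 `Cc1nnc(-c2nsc3ccccc23)o1` gives 43%. Compound 2 `CCc1nnc(-c2nsc3ccccc23)o1` gives 10%, and compound 3 `CNc1nnc(-c2nsc3ccccc23)o1` gives 10%; these two stand level in this assay. The change from compound 1 to compound 2, (methyl in place of hydrogen on a saturated chain carbon bound to an aromatic carbon), made the step of a number 33 percentage points lower from compound 1 to compound 2 (beyond the scatter). The cores of compound 1 and compound 3 differ by methylamino in place of methyl on an aromatic carbon. Compound 4 `CCNc1nnc(-c2nsc3ccccc23)o1` is not yet measured in this assay; it differs from compound 3 by methyl in place of hydrogen on a saturated chain carbon bound to a nitrogen on an aromatic ring, the same kind of change as from compound 1 to compound 2, though here the saturated chain carbon is bound to a nitrogen on an aromatic ring and not to an aromatic carbon. A downward step as large as the earlier one is not expected because compound 3 gives only 10%; a small step is expected instead, a number 5 percentage points lower from compound 3 to compound 4 (within the scatter). Compound 4 is thus estimated at 5%, expected between 0% and 20%.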

Compound 4, a percentage reported as inhibition, in the whole organism at one dose (the size of the read-out at that dose, not a potency): 53%
The estimate for compound 4 lay 48 percentage points below the measured number, and the stated range ends below it.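

In this assay the added methyl does not carry over from one core to the other, and its step runs in opposite directions on the two: the same change on two cores in this assay, a number 33 percentage points lower (beyond the scatter) from compound 1 to compound 2 and a number 43 percentage points higher (beyond the scatter) from compound 3 to compound 4, 76 percentage points apart, beyond the scatter of two such steps. On the core of compound 3 the added methyl gives a number 43 percentage points higher from compound 3 to compound 4 (beyond the scatter), ethylamino in place of ethyl gives a number 43 percentage points higher from compound 2 to compound 4 (beyond the scatter), and ethylamino in place of methyl gives a number 10 percentage points higher from compound 1 to compound 4 (within the scatter). Within these four compounds the direction of the step depends on the core; this does not show why, nor how the change would read on any further core, and each core supplies only a single pair at one dose.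

On these data alone, whether a longer chain such as propylamino, or dimethylamino, would read like ethylamino or like methylamino stays open.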